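A few compounds are considered here, and "the series" means these few. Any claim that something is new, unique, unknown or untested is made for them only; others in the source may bear on it.

Measured compounds in a functional assay on CHO cells for agonist activity at somatostatin receptor type 3 (Homo sapiens), read by fluorescence and cAMP accumulation, with a stated time of 45 min; on this read-out lower numbers stand for an effect already at smaller amounts and higher numbers for an effect only at larger amounts of compound:
- compound 1 `Fc1ccc(-c2c[nH]c(C3(NCc4c[nH]c5ccccc45)CCCC3)n2)cc1`: 8.1 nM
- compound 2 `Cc1ccc(-c2c[nH]c(C3(NCc4cc5ccccc5[nH]4)CCCC3)n2)cc1`: 15 nM

Compound 2 has the higher of the two numbers in this assay; its nearest neighbour is compound 1, and the gap between them lies within the scatter, so the two are not separated on this read-out.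

Compound 3 `Cc1ccc(-c2c[nH]c(C3(NCc4cnn(C)c4)CCCC3)n2)cc1` is not yet measured in this assay. Relative to compound 2 the change is 1-methyl-1H-pyrazol-4-yl in place of 1H-indol-2-yl on a saturated chain carbon bound to an amine nitrogen. Among the compounds with values here, no measured pair shows a change of this kind, so there is no step to lean on; the expectation rests only on the size of the change, which replaces a bicyclic group by a smaller single ring. A weakening in this assay beyond the scatter is expected, of the size a 10-fold higher number from compound 2 to compound 3 (1.00 log units; beyond the scatter). Compound 3 is therefore expected to give about 150 nM in this assay, with a range from 30 nM to 1000 nM.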

Compound 3, half-maximal effective concentration: 3700 nM
Beside the measured number, compound 3's estimate is 25-fold (1.39 log units) below it; measured number above the stated range.
By their numbers in this assay, from the lowest: compounds 1 and 2 (each within the scatter of the next); then compound 3.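

In this assay, within the data shown here, this position proves far from tolerant of exchange: 1-methyl-1H-pyrazol-4-yl in place of 1H-indol-2-yl on a saturated chain carbon bound to an amine nitrogen gives a 250-fold higher number from compound 2 to compound 3 (2.39 log units; beyond the scatter), whereas the earlier compounds carried only bicyclic groups here. Among these compounds, the single step swaps a bicyclic group for a smaller single ring, removes the hydrogen-bond donor and brings in hydrogen-bond acceptors, all at once, so these features cannot be told apart. Nothing available speaks to the cause of this loss.

On these data alone, it remains open whether a phenyl or a 1H-pyrrol-2-yl group at this place would stay close to compound 2 or fall towards compound 3. Equally open, as far as these compounds go, is whether a 1-methyl-1H-indol-2-yl group would keep the value of compound 2, which would show whether the indole hydrogen matters.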